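The compounds below may be only part of what the source reports. "The series", "measured", "known", "first", "only" and "open" are said of these compounds alone.

Compounds measured in a functional assay on cells for agonist activity at G-protein coupled receptor 52 (Homo sapiens), read by AlphaScreen and cAMP accumulation, with a stated time of 30 min; on this read-out higher numbers stand for larger maximal responses and lower numbers for smaller maximal responses:
- compound 1, `COc1cccc(Cc2nc(C)c(-c3ccc(C(N)=O)c(C)c3)s2)c1`: 85%
- compound 2, `Cc1cc(-c2sc(Cc3cccc(Cl)c3)nc2C)ccc1C(N)=O`: 75%

Among the compounds with values here, compound 2 stands lowest of the two numbers; its nearest neighbour is compound 1, and the only step between them, a number 10 percentage points lower from compound 1 to compound 2 (within the scatter), lies within the scatter. Compound 3, `Cc1cc(-c2sc(Cc3ccccc3Cl)nc2C)ccc1C(N)=O`, is not yet measured. It differs from compound 2 by 2-chlorophenyl in place of 3-chlorophenyl on a saturated chain carbon bound to an aromatic carbon. Within the data shown here, the one measured step exchanges chloro for methoxy and says nothing about 2-chlorophenyl in place of 3-chlorophenyl, so no measured step bears directly on this change. With nothing but a within-scatter step to draw on, no shift beyond the scatter is expected in this assay; the step of a number 5 percentage points lower from compound 2 to compound 3 (within the scatter) is expected to be small, if anything slightly downward given the wide range of outcomes such a rearrangement can give. Compound 3 is therefore estimated at 70%, expected to fall between 45% and 90%.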

Compound 3, largest response reached (Emax), in percent of the reference or control that the assay uses: 51%
Beside the measured number, compound 3's estimate is 19 percentage points above it, and the stated range covers the measured number.
By their numbers in this assay, from the lowest: compound 3; then compounds 2 and 1 (each within the scatter of the next).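

In this assay, 2-chlorophenyl in place of 3-chlorophenyl on a saturated chain carbon bound to an aromatic carbon gives a number 24 percentage points lower from compound 2 to compound 3 (beyond the scatter) even though the two groups hold the same atoms, so the response at this position depends on where the chloro sits and not only on which group is present. The exchange of chloro for methoxy had given only a number 10 percentage points lower from compound 1 to compound 2 (within the scatter), while 2-chlorophenyl in place of 3-methoxyphenyl gives a number 34 percentage points lower from compound 1 to compound 3 (beyond the scatter) in the same series. No measurement shown here accounts for this loss of maximal response. As far as these compounds go, whether moving a methoxy in the same way costs as much remains open, since the rearrangement has been seen with chloro alone. Also open, from the compounds shown here alone, is how a nitrile or an amine on this aromatic ring would fare.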